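Aryl swap on the enone series: outlook for compound 4

The source may report more compounds than this note shows. Statements on the series, on what has been measured and on what is new or still open speak of the compounds shown alone.

Compound 2 `COc1ccc(/C=C2\CCc3cc(OC)c(OC)cc3C2=O)cc1` is read in a functional assay on Jurkat cells (Homo sapiens) for antiproliferative activity, read by MTT assay (on this read-out lower numbers stand for stronger inhibition and higher numbers for weaker inhibition), only as a limit of the assay, and in that assay compound 2 gives > 50000 nM. Compound 3 `COc1ccc(/C=C2\CCc3cc(OC)c(OC)cc3C2=O)c(OC)c1` is likewise reported as a limit, giving > 50000 nM in this assay. Within the data shown here, the one change between them, methoxy in place of hydrogen on an aromatic carbon, yields a step that the two limits leave unreadable from compound 2 to compound 3, so that step carries no readable size. Among the measured compounds shown here, the only numeric value in the set comes from compound 1 `COc1cc2c(cc1OC)C(=O)/C(=C/c1cccc([N+](=O)[O-])c1)CC2`, which gives 9000 nM in this assay. So compound 2 stands at the limit of > 50000 nM in this assay, at which 2 of the 3 values shown sit, with no measured step from it that can be sized.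

Compound 4 `COc1cc2c(cc1OC)C(=O)/C(=C/c1cc(C)cc(C)c1)CC2` differs from compound 2 by 3,5-dimethylphenyl in place of 4-methoxyphenyl on a double-bonded chain carbon bound to a double-bonded ring carbon. No measured step bears on this change other than the unreadable one from compound 2 to compound 3, so neither direction nor size follows from the shown numbers. The step in this assay is therefore expected to be an at least 1.6-fold lower number from compound 2 to compound 4 (0.22 log units; that floor lies within the scatter), with a fair chance that only a limit is returned. Compound 4 is estimated at 30000 nM, within a range from 8000 nM to 100000 nM.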

Compound 4, half-maximal inhibitory concentration: 4000 nM
Beside the measured number, compound 4's estimate is 7.5-fold (0.88 log units) above it; measured number outside the range, below it.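

In this assay, among these compounds, 3,5-dimethylphenyl in place of 4-methoxyphenyl on a double-bonded chain carbon bound to a double-bonded ring carbon gives an at least 12-fold lower number from compound 2 to compound 4 (1.09 log units; beyond the scatter), the first step in this aryl series with a readable size. Compound 2 is a limit and not a number, so that size is only a floor: the limit of > 50000 nM in this assay, at which 2 of the 4 values shown sit. The two groups match in heavy-atom count and aromatic ring but differ in the oxygen and hydrogen-bond acceptor of 4-methoxyphenyl, and this one step cannot separate removing the methoxy from adding the two methyl groups.

On these data alone, the step from compound 2 to compound 3 cannot be read, so the effect of a further methoxy on the aryl ring stays open. As far as these compounds go, it also remains open whether 3-methylphenyl, 3,5-dichlorophenyl or an aryl group carrying an amine would match compound 4.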